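This account rests on a few compounds, and the source may have more. Where it says the series, first, only, none or still open, it means among the compounds named here.

Of the compounds shown here, three built on one shared core have been measured in a functional assay on HT cells (Homo sapiens) for antiproliferative activity, read by fluorescence, with a stated time of 72 h; a lower number here means a stronger inhibitor of growth, a higher number a weaker inhibitor of growth. Compound 1 `CC(C)c1n[nH]c2c(NCc3ccc(-c4ccccn4)cc3)nc(SCC(N)CN)nc12` gives 480 nM, compound 2 `CC(C)c1n[nH]c2c(NCc3ccc(-c4ccccn4)cc3)nc(SCC3CNC(=O)O3)nc12` gives 80 nM, and compound 3 `CC(C)c1n[nH]c2c(NCc3ccc(-c4ccccn4)cc3)nc(SC3CCCC3O)nc12` gives 567 nM. Compound 2 thus stands at the lowest number of the three, with a 6.0-fold lower number from compound 1 to compound 2 (0.78 log units; beyond the scatter) and a 7.1-fold higher number from compound 2 to compound 3 (0.85 log units; beyond the scatter). Compound 4 `CC(C)c1n[nH]c2c(NCc3ccc(-c4ccccn4)cc3)nc(SCCNC(N)=O)nc12` is not yet measured; it differs from compound 2 by ureidomethyl in place of 2-oxo-1,3-oxazolidin-5-yl on a saturated chain carbon bound to a sulfur. Both measured steps that touch compound 2 show that exchanging the group on a saturated chain carbon bound to a sulfur moves the number beyond the scatter, and in each case the alternative to the 2-oxo-1,3-oxazolidin-5-yl group gave the higher number. A modest rise is therefore expected, a 2.8-fold higher number from compound 2 to compound 4 (0.44 log units; beyond the scatter). Compound 4 is estimated at 220 nM, between 80 nM and 600 nM.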

Compound 4, concentration for 50% growth inhibition: 240 nM
For compound 4 the middle estimate is 1.1-fold (0.04 log units) below the measured one; the range from low to high includes it.
By their numbers in this assay, from the lowest: compound 2; then compounds 4, 1 and 3 (each within the scatter of the next, the first and the last beyond it).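

In this assay opening the 2-oxo-1,3-oxazolidin-5-yl ring into the ureidomethyl chain raises the number beyond the scatter (a 3.0-fold higher number from compound 2 to compound 4 (0.48 log units; beyond the scatter)), so compound 2 stays lowest of the four. Among the other exchanges on the sulfur, 2-ureidoethyl beats 2-hydroxycyclopentyl (a 2.4-fold lower number from compound 3 to compound 4 (0.37 log units; beyond the scatter)), whereas ureidomethyl and 1,2-diaminoethyl cannot be told apart (a 2.0-fold lower number from compound 1 to compound 4 (0.30 log units; within the scatter)). No measured evidence accounts for these differences. The compounds shown leave open how a carboxylic acid, or a longer chain ending in the ureido group, would fare at this place.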